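Inverting one ring stereocentre in a sesquiterpene ester

The source may hold more compounds than are shown below. What is called first, only, known or untested is meant among the compounds shown, and "the series" means these compounds.

Three related esters have been tested in a functional assay on RS4-11 cells (Homo sapiens) for cytotoxicity, read by MTT assay, with a stated time of 72 h; a higher number here means a weaker inhibitor, a lower number a stronger inhibitor. Compound 1 `CC1=C[C@H](OC(=O)c2ccc(O)cc2)[C@@H]2[C@](C)(CC[C@@]2(O)C(C)C)CC1=O` gives 28200 nM in this assay. Compound 2 `COc1ccc(C(=O)O[C@H]2CC(C)=C[C@H](O)[C@@]3(C)[C@@H](OC(C)=O)C[C@@](O)(C(C)C)[C@H]23)cc1` gives 34400 nM in this assay, and compound 3 `COc1ccc(C(=O)O[C@H]2CC(C)=CC[C@@]3(C)CC[C@@](O)(C(C)C)[C@H]23)cc1` gives 17600 nM in this assay. Compound 2 has the highest of the three numbers, but its distance to compound 1 and to compound 3 both lie within the usual scatter, so the three cannot be ranked against one another.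

Compound 4 `COc1ccc(C(=O)O[C@H]2CC(C)=C[C@@H](O)[C@@]3(C)[C@@H](OC(C)=O)C[C@@](O)(C(C)C)[C@H]23)cc1` has not yet been measured in this assay. It differs from compound 2 in this way: the two compounds have the same atoms and bonds and differ only in configuration as drawn: 1 of 6 stereo elements differ; a stereocentre at a saturated ring carbon is drawn S in compound 2 and R in compound 4. Within the data shown here, no pair of measured compounds shows what such a change does in this assay, so no step can be read from the data.

With nothing to indicate a direction, compound 4 is expected to give a number close to that of compound 2, a step of a 1.1-fold lower number from compound 2 to compound 4 (0.03 log units; within the scatter) that stays within the scatter. The estimate for compound 4 in this assay is 32000 nM, with a range from 12000 nM to 90000 nM.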

Compound 4, half-maximal inhibitory concentration: 70400 nM
Compound 4: the middle estimate sits 2.2-fold (0.34 log units) below what was measured, within the range that was stated.
By their numbers in this assay, from the lowest: compounds 3, 1 and 2 (each within the scatter of the next); then compound 4.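

Inverting this saturated ring carbon from S to R gives a 2.0-fold higher number from compound 2 to compound 4 (0.31 log units; beyond the scatter) in this assay, a modest step that lies just beyond the scatter. Among these compounds, the earlier compounds could not show this, since no two of them differed in one place, so this is the first sign that the drawn configuration at this position affects the read-out, with the R form giving the higher number. The step can be traced to this single stereocentre alone: the fact that compounds 2 and 4 differ only in the configuration as drawn.

This single pair leaves open whether the same inversion would have a comparable effect in a compound with a different ester or other substituents on the shared core. It also leaves open what an amine in place of the hydroxyl on this carbon would do in either configuration.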